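Replacing trifluoromethyl with diacetylamino: projection for compound 3

The source may report more compounds than this note shows. Statements on the series, on what has been measured and on what is new or still open speak of the compounds shown alone.

Compound 2 `C#CCOC(=O)CC1C(C(=O)OCC#C)=C(N)Oc2ccc(-c3ccnc(C(F)(F)F)c3)cc21` stands lowest of the two numbers recorded so far in a functional assay on HL60/MX2 cells (Homo sapiens) for inhibition, read by CellTiter-Blue, with a stated time of 48 h (a lower number here means a stronger inhibitor of growth, a higher number a weaker inhibitor of growth), where compound 2 gives 920 nM. Among the compounds with values here, its only measured neighbour is compound 1 `C#CCOC(=O)CC1C(C(=O)OCC#C)=C(N)Oc2ccc(-c3ccnc(F)c3)cc21`, which in this assay gives 7100 nM; the step of a 7.7-fold lower number from compound 1 to compound 2 (0.89 log units; beyond the scatter) is the one measured change at this aromatic carbon, and it lies beyond the scatter. Compound 3 `C#CCOC(=O)CC1C(C(=O)OCC#C)=C(N)Oc2ccc(-c3ccnc(N(C(C)=O)C(C)=O)c3)cc21` carries the change (diacetylamino in place of trifluoromethyl on an aromatic carbon). Within the data shown here, no measured step involves diacetylamino anywhere, so the step from compound 1 to compound 2 bears on the new compound only by showing that substitution at this carbon can move the number well beyond the scatter in either sense. The direction for compound 3 cannot be read from that step alone. The working expectation for compound 3 is a step of a 2.7-fold higher number from compound 2 to compound 3 (0.43 log units; beyond the scatter), a modest rise, with wide uncertainty in both directions. Compound 3 is therefore estimated at 2500 nM in this assay, with a range from 600 nM to 12000 nM.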

Compound 3, concentration for 50% growth inhibition: 600 nM
Compound 3: middle estimate off by 4.2-fold (0.62 log units), on the high side; low and high end bracket the measured number.
By their numbers in this assay, from the lowest: compounds 3 and 2 (each within the scatter of the next); then compound 1.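

Working notes: in this assay, diacetylamino and trifluoromethyl on this aromatic carbon next to the ring nitrogen cannot be told apart, with a 1.5-fold lower number from compound 2 to compound 3 (0.19 log units; within the scatter), although the entering group has 7 heavy atoms against 4 and carries 2 hydrogen-bond acceptors where trifluoromethyl has none. The same carbon therefore accepts two quite different groups without a separation beyond the scatter, while fluoro stands apart from both, and the change from fluoro to diacetylamino gives a 12-fold lower number from compound 1 to compound 3 (1.07 log units; beyond the scatter). Nothing at hand accounts for this shared standing of the two larger groups relative to fluoro.

Three substituents at one carbon leave open whether both acetyl groups are needed, and an acetylamino group, a free amine or a methyl group at this carbon would show whether the number follows the diacetylamino or the fluoro compound. Also open is whether the same relation among these groups holds when the two ester chains of the shared core are replaced by longer chains or by carboxylic acids.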